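Swapping Ethoxy for Butylamino: Tolerance Expected to Hold

The source may hold more compounds than are shown below. What is called first, only, known or untested is meant among the compounds shown, and "the series" means these compounds.

Three compounds of one shared core were tested in an ADME assay on Akata cells (Homo sapiens) for cytotoxicity, with a stated time of 7 days; a lower number here means that less compound is tolerated, a higher number that more compound is tolerated:
Compound 1, `CCOc1nc(N)nc2c1ncn2/C=C1/CC1(CO)CO`, gives > 20000 nM, which is a limit of the assay rather than a number.
Compound 2, `Nc1nc(NC2CC2)c2ncn(/C=C3/CC3(CO)CO)c2n1`, gives > 20000 nM, again a limit.
Compound 3, `CCCCSc1nc(N)nc2c1ncn2/C=C1/CC1(CO)CO`, gives > 20000 nM, again a limit.

Compound 1 therefore stands at the limit of > 20000 nM in this assay, at which 3 of the 3 values shown sit, and so do the other two. The change from compound 1 to compound 4, `CCCCNc1nc(N)nc2c1ncn2/C=C1/CC1(CO)CO`, is butylamino in place of ethoxy on an aromatic carbon. Two measured steps leave from compound 1 and touch the same carbon: a step that the two limits leave unreadable from compound 1 to compound 2 and a step that the two limits leave unreadable from compound 1 to compound 3; the third, a step that the two limits leave unreadable from compound 2 to compound 3, likewise cannot be read. Because every value sits at the limit of > 20000 nM in this assay, at which 3 of the 3 values shown sit, none of these steps shows a size, so no direction can be drawn from them for this assay. What they do show is that cyclopropylamino and butylsulfanyl at this carbon both leave the compound tolerated up to the limit. The expectation for compound 4 is that butylamino behaves the same way, so the step that the limit leaves unreadable from compound 1 to compound 4 is expected to be none beyond the scatter. Compound 4 is estimated at 25000 nM, with a range from 10000 nM to 60000 nM, and most likely reported once more only as a limit.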

Compound 4, half-maximal cytotoxic concentration: > 24000 nM
Compound 4: a limit, no number (the forecaster's own chance of this, stated with the estimate: 85%); the middle value is on the limit's open side.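

In this assay, compound 4 gives > 24000 nM, which is a limit and not a number. Within the data shown here, compound 1, compound 2 and compound 3 also gave only limits, so no step between any two of these four compounds can be read. As far as these compounds go, the concentration at which any of them becomes toxic to the cells, and whether the group on this aromatic carbon affects it, remains open.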